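The compounds below may be only part of what the source reports. "The series", "measured", "known", "first", "only" and "open" are said of these compounds alone.

Measured compounds in an ADME assay on HEL cells (Homo sapiens) for cytotoxicity, with a stated time of 3 days; a higher number here means that more compound is tolerated, a lower number that less compound is tolerated:
Compound 1 `CC(C)CC1(Cc2ccccc2)OS(=O)(=O)C=C1OCc1ccccc1` gives 102000 nM.
Compound 2 `CCC1(Cc2ccccc2)OS(=O)(=O)C=C1OCc1ccc(Cl)cc1` gives > 200000 nM, which is a limit of the assay and not a number.
Compound 3 `CCC1(Cc2ccccc2)OS(=O)(=O)C=C1OCc1ccc(C(F)(F)F)cc1` gives 99000 nM.

Compound 2 stands at the limit of > 200000 nM in this assay, at which 1 of the 3 values shown sits, so its true position is known only as a limit. Compound 4 `CCC1(Cc2ccccc2)OS(=O)(=O)C=C1OCCc1ccccc1` differs from compound 2 by benzyl in place of 4-chlorophenyl on a saturated chain carbon bound to an oxygen on an unsaturated carbon, which, cut one bond further out, reads 4-chlorobenzyl to phenethyl. Among the measured compounds shown here, no measured step removes a chloro in this way. For the measured compounds named here, the only measured step that starts from compound 2 is an at least 2.0-fold lower number from compound 2 to compound 3 (0.30 log units; that floor lies within the scatter), and its floor lies within the scatter. Compound 1 and compound 3 give values close to each other, whereas compound 2 gives only a limit. On these numbers no step beyond the scatter is expected in this assay from compound 2 to compound 4. The expected step of an at least 1.3-fold lower number from compound 2 to compound 4 (0.12 log units; that floor lies within the scatter) therefore mostly reflects that compound 2 is known only as a limit. Compound 4 is estimated at 150000 nM, with a range from 70000 nM to 300000 nM.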

Compound 4, half-maximal cytotoxic concentration: 48000 nM
Compound 4: the middle estimate sits 3.1-fold (0.49 log units) above what was measured; the whole stated range lies above it.
By their numbers in this assay, from the lowest: compound 4; then compounds 3 and 1 (each within the scatter of the next). At a limit, above all of these: compound 2.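

In this assay, the change from 4-chlorophenyl to benzyl on a saturated chain carbon bound to an oxygen on an unsaturated carbon gives an at least 4.1-fold lower number from compound 2 to compound 4 (0.61 log units; beyond the scatter). This is the first step from compound 2 shown to lie beyond the scatter, so this position can change how much compound is tolerated even though the count of heavy atoms in the exchanged groups stays the same. The true step may be larger, because compound 2 stands at a limit of the assay and not at a number: the limit of > 200000 nM in this assay, at which 1 of the 4 values shown sits.

Since 4-chlorobenzyl gives way to phenethyl in a single change, the compounds shown leave open whether losing the chloro or changing the chain matters more. They also leave open how a longer chain such as phenylpropyl, or an amine on the phenyl ring, would read here.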